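Lengthening the alkenyloxy chain on the core: compound 4

This account rests on a few compounds, and the source may have more. Where it says the series, first, only, none or still open, it means among the compounds named here.

Measured so far:
- compound 1, `C=CCCCCOc1ccccc1-c1cnc(OCCC=C)n1C`: 29000 nM
- compound 2, `C=CCCCCOc1ccccc1-c1cnc(OCCCC=C)n1C`: 3000 nM
- compound 3, `C=CCCCCOc1ccccc1-c1cnc(OCCCCC=C)n1C`: 4000 nM

Three compounds share one core and differ only in the alkenyloxy chain on the heteroaromatic oxygen. In a functional assay on T98G cells (Homo sapiens) for inhibition, read by colorimetric assay and MTT assay, with a stated time of 72 h (a higher number here means a weaker inhibitor, a lower number a stronger inhibitor), compound 3 gives the second highest of the three numbers. Its nearest neighbour is compound 2, and the step of a 1.3-fold higher number from compound 2 to compound 3 (0.12 log units; within the scatter) lies within the scatter, so no order between the two can be read. Its furthest neighbour is compound 1, and the step of a 7.3-fold lower number from compound 1 to compound 3 (0.86 log units; beyond the scatter) is beyond the scatter, as is a 9.7-fold lower number from compound 1 to compound 2 (0.99 log units; beyond the scatter).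

Compound 4, `C=CCCCCCOc1ncc(-c2ccccc2OCCCCC=C)n1C`, is the next member of the series. It differs from compound 3 by allyl in place of vinyl on a saturated chain carbon, four bonds along the chain from an oxygen on an aromatic ring.

For the measured compounds named here, the steps that bear on this change are the three chain extensions already seen. The first extension, from compound 1, was the modest one; the second, a 1.3-fold higher number from compound 2 to compound 3 (0.12 log units; within the scatter), fell within the scatter. Compound 4 carries the same kind of change one bond further out, so the step of no change at the digits printed from compound 3 to compound 4 (within the scatter) is expected to stay within the scatter in this assay. Compound 4 is therefore estimated at 4000 nM, in a range from 1500 nM to 11000 nM.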

Compound 4, half-maximal inhibitory concentration: 63000 nM
For compound 4 the middle estimate is 16-fold (1.20 log units) below the measured one, outside the stated range (above it).
By their numbers in this assay, from the lowest: compounds 2 and 3 (each within the scatter of the next); then compound 1; then compound 4.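

The earlier compounds shown here showed one clear drop in the number on the first extension and then no readable change, but this further extension reverses that direction in this assay: there is a 16-fold higher number from compound 3 to compound 4 (1.20 log units; beyond the scatter), and a 21-fold higher number from compound 2 to compound 4 (1.32 log units; beyond the scatter). Even against the shortest chain shown there is a 2.2-fold higher number from compound 1 to compound 4 (0.34 log units; beyond the scatter), so the chain of compound 4 gives the weakest inhibitor of the four, and the series has no steady trend with chain length, with compounds 2 and 3 forming a low point that cannot be ordered within itself. The same added length therefore has opposite effects depending on the chain it extends: the same change on two cores in this assay, a 9.7-fold lower number (0.99 log units; beyond the scatter) from compound 1 to compound 2 and a 16-fold higher number (1.20 log units; beyond the scatter) from compound 3 to compound 4, 150-fold (2.18 log units) apart, beyond the scatter of two such steps. The larger extension reverses in the same way: the same change on two cores in this assay, a 7.3-fold lower number (0.86 log units; beyond the scatter) from compound 1 to compound 3 and a 21-fold higher number (1.32 log units; beyond the scatter) from compound 2 to compound 4, 150-fold (2.18 log units) apart, beyond the scatter of two such steps.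

The compounds shown leave open whether a still longer chain would stay as weak as compound 4 or recover, and whether the sharp rise follows chain length alone or needs the terminal double bond, which a fully saturated alkyl chain of the same length would separate. They also leave open whether a chain ending in an amine or a carboxylic acid would behave the same way at this position.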